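This account rests on a few compounds, and the source may have more. Where it says the series, first, only, none or still open, it means among the compounds named here.

Measured so far:
compound 1 `Nc1scc(CN2CCN(c3ccc(Cl)cc3Cl)CC2)c1C(=O)c1ccc(Cl)cc1` — 0%
compound 2 `Nc1scc(CN2CCN(c3cccc(Cl)c3Cl)CC2)c1C(=O)c1ccc(Cl)cc1` — 0%

In an assay on CHO cells for displacement of a labelled ligand from adenosine receptor A3 (Homo sapiens), read by scintillation counting, with a stated time of 120 min, tested at 10 uM (on this read-out lower numbers stand for less inhibition and higher numbers for more inhibition at the one concentration tested (going by the name of the read-out)), compound 1 gives 0% and compound 2 gives 0%; the step of no change at the digits printed from compound 1 to compound 2 (within the scatter) is flat. Compound 2 therefore stands level with compound 1, with no measurable inhibition in either.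

Compound 3 `Nc1scc(CN2CCN(c3ccccc3F)CC2)c1C(=O)c1ccc(Cl)cc1` differs from compound 2 by 2-fluorophenyl in place of 2,3-dichlorophenyl on an amine nitrogen in a ring. For the measured compounds named here, the one measured step, no change at the digits printed from compound 1 to compound 2 (within the scatter), varied the substitution of the aryl group on the ring nitrogen without any effect, which is the only guidance for this change. No step beyond the scatter is therefore expected; the expected change is no change at the digits printed from compound 2 to compound 3 (within the scatter). For compound 3 the estimate in this assay is 0%, range 0% to 12%.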

Compound 3, a percentage reported as inhibition, at one concentration (the size of the read-out at that concentration, not a potency): 0%
Estimate against measurement, compound 3: no gap at the digits printed; low and high end bracket the measured number.
By their numbers in this assay, from the lowest: compounds 1, 2 and 3 (each within the scatter of the next).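

In this assay, 2-fluorophenyl in place of 2,3-dichlorophenyl gives no change at the digits printed from compound 2 to compound 3 (within the scatter), and 2-fluorophenyl in place of 2,4-dichlorophenyl gives no change at the digits printed from compound 1 to compound 3 (within the scatter). The flat result on this amine nitrogen therefore holds not only for a different arrangement of two chlorines but also for a single fluorine on the phenyl group. No evidence bears on this result.

From the compounds shown here alone, whether a methoxy group or a carboxylic acid on this phenyl group would give any inhibition stays open. So does whether a longer chain in its place would do so.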